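The source may report more compounds than this note shows. Statements on the series, on what has been measured and on what is new or still open speak of the compounds shown alone.

Working notes on the shared core of compound 1 `O=c1cc(CNCc2ccccc2)oc2ccc(O)c(O)c12` in an ADME assay on Huh-7 cells (Homo sapiens) for cytotoxicity; on this read-out lower numbers stand for higher toxicity in this test and higher numbers for lower toxicity in this test. Compound 1 gives > 100000 nM in this assay, and this value is a limit of the assay rather than a number. Compound 2 `O=c1cc(CNCc2ccccc2O)oc2ccc(O)c(O)c12` gives > 100000 nM in this assay, again a limit. Going by the values given here, the one measured step, a step that the two limits leave unreadable from compound 1 to compound 2, cannot be sized because of the limit of > 100000 nM in this assay, at which 2 of the 2 values shown sit. Compound 3 `Cc1ccc(CNCc2cc(=O)c3c(O)c(O)ccc3o2)cc1` is the unmeasured case: methyl in place of hydrogen on an aromatic carbon. The step from compound 1 to compound 2 is the only one that bears on it, and its size is hidden by the two limits, so no direction beyond the scatter can be set for compound 3 in this assay. Compound 3 is expected to sit at the limit as well, estimated at 150000 nM with a range from 50000 nM to 500000 nM. The step that the limit leaves unreadable from compound 1 to compound 3 is accordingly expected to be none beyond the scatter.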

Compound 3, half-maximal cytotoxic concentration: > 100000 nM
Compound 3 was reported as a limit; the forecaster's own chance of this, stated with the estimate: 85%; the middle value does not contradict the limit.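

Compound 3 is, like compound 1 and compound 2, a limit in this assay, so neither new step, from compound 1 or from compound 2, can be read: the limit of > 100000 nM in this assay, at which 3 of the 3 values shown sit. The compounds shown leave open whether hydroxy or methyl in place of hydrogen changes the half-maximal cytotoxic concentration at all.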